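The source may hold more compounds than are shown below. What is called first, only, known or untested is meant among the compounds shown, and "the series" means these compounds.

Compound 1 `O=C1[C@@H](NS(=O)(=O)c2cc3ccc(Cl)nc3s2)CCN1Cc1cc2[nH]cccc-2n1` gives 23% in an assay on isolated protein for inhibition of coagulation factor X (Oryctolagus cuniculus), tested at 1 uM; on this read-out lower numbers stand for less inhibition and higher numbers for more inhibition at the one concentration tested (going by the name of the read-out). Compound 2 `O=C1[C@@H](NS(=O)(=O)c2ccc(-c3ccon3)s2)CCN1Cc1cc2c[nH]ccc-2n1` gives 17%. Compound 3 `O=C1[C@@H](NS(=O)(=O)c2cc3ccnc(Cl)c3s2)CCN1Cc1cc2[nH]cccc-2n1` gives 45%.

Compound 3 stands highest of the three, beyond the scatter from compound 1 and from compound 2. Compound 4 `O=C1[C@@H](NS(=O)(=O)c2cc3ccnc(Cl)c3s2)CCN1Cc1cc2c[nH]ccc-2n1` differs from compound 3 by a group of 9 heavy atoms (7 carbon, 2 nitrogen; one five-membered aromatic ring with 1 hetero atom, one six-membered aromatic ring with 1 hetero atom) in place of a group of 9 heavy atoms (7 carbon, 2 nitrogen; one five-membered aromatic ring with 1 hetero atom, one six-membered aromatic ring with 1 hetero atom), on a saturated chain carbon bound to an amide-type nitrogen in a ring. Among the measured compounds shown here, the single measured step, a number 22 percentage points higher from compound 1 to compound 3 (beyond the scatter), concerns the group on the sulfonyl sulfur and so does not bear on this change. Compound 2 carries the same group as compound 4 at this place, but it differs from compound 1 in two places, so those two values alone cannot isolate the effect. He therefore expects a step of a number 7 percentage points lower from compound 3 to compound 4 (within the scatter), within the scatter. His estimate for compound 4 is 38%, ranging from 20% to 58%.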

Compound 4, a percentage reported as inhibition, at one concentration (the size of the read-out at that concentration, not a potency): 25%
Estimate against measurement, compound 4: 13 percentage points above; the measured number falls inside the stated range.
By their numbers in this assay, from the lowest: compounds 2, 1 and 4 (each within the scatter of the next); then compound 3.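

In this assay, the place on a saturated chain carbon bound to an amide-type nitrogen in a ring proves sensitive: with the same atoms joined differently, the change gives a number 20 percentage points lower from compound 3 to compound 4 (beyond the scatter) and thereby a shift beyond the scatter. With this entering group held constant, changing the group on the sulfonyl sulfur gives a number 8 percentage points higher from compound 2 to compound 4 (within the scatter) and stays within the scatter. No measured evidence shown explains either step.

Going by these compounds, whether the first step holds with other groups on the sulfonyl sulfur remains open. So does the effect of a primary amine or a carboxylic acid at this place.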